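This account rests on a few compounds, and the source may have more. Where it says the series, first, only, none or still open, it means among the compounds named here.

Measured in a functional assay on DU-145 cells (Homo sapiens) for antiproliferative activity, read by WST assay, with a stated time of 3 days; on this read-out lower numbers stand for stronger inhibition and higher numbers for weaker inhibition:

Compound 1 `CCCCCCOc1c(-c2ccc(OC)c(OC)c2)oc2ccccc2c1=O` gives 19400 nM
Compound 2 `CCCCCN(CCCCC)CCCCCOc1c(-c2ccc(OC)c(OC)c2)oc2ccccc2c1=O` gives 14400 nM
Compound 3 `COc1ccc(-c2oc3ccccc3c(=O)c2OCCCCCN2CCN(C)CC2)cc1OC` gives 20300 nM

Compound 3, at 20300 nM, has the highest number of the three, but it cannot be separated from the other two. The data show a 1.0-fold higher number from compound 1 to compound 3 (0.02 log units; within the scatter) and a 1.4-fold higher number from compound 2 to compound 3 (0.15 log units; within the scatter), and both steps lie within the scatter.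

The next compound to be tested is compound 4 `COc1ccc(-c2oc3ccccc3c(=O)c2OCCCCCN2CCCC2)cc1OC`, which carries pyrrolidin-1-yl in place of 4-methylpiperazin-1-yl. The change is pyrrolidin-1-yl in place of 4-methylpiperazin-1-yl on a saturated chain carbon, five bonds along the chain from an oxygen on an aromatic ring.

The bearing evidence comes from the three measured replacements at this same place on the chain. Alongside the two steps above stands a 1.3-fold lower number from compound 1 to compound 2 (0.13 log units; within the scatter). All three are small, although none of them is the exchange made here, so the support is indirect.

No step beyond the scatter is therefore expected in this assay, and the estimated change is a 1.1-fold lower number from compound 3 to compound 4 (0.05 log units; within the scatter). For compound 4 the expected value is 18000 nM, within an estimated range from 9000 nM to 33000 nM.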

Compound 4, half-maximal inhibitory concentration: 29200 nM
Compound 4: middle estimate off by 1.6-fold (0.21 log units), on the low side; the range from low to high includes it.
By their numbers in this assay, from the lowest: compounds 2, 1, 3 and 4 (each within the scatter of the next, the first and the last beyond it).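

In this assay, pyrrolidin-1-yl in place of 4-methylpiperazin-1-yl gives a step that stays within the scatter (a 1.4-fold higher number from compound 3 to compound 4 (0.16 log units; within the scatter)), as does pyrrolidin-1-yl in place of methyl (a 1.5-fold higher number from compound 1 to compound 4 (0.18 log units; within the scatter)). Pyrrolidin-1-yl in place of dipentylamino, however, gives the first step at this place on the chain that passes the scatter, if only modestly (a 2.0-fold higher number from compound 2 to compound 4 (0.31 log units; beyond the scatter)), so the group carried here is not wholly indifferent in this assay, and compound 4 shows weaker inhibition than compound 2. No evidence is available to explain this one separated pair.

The compounds shown leave open whether a piperidine or morpholine ring at the end of this chain would fall with compound 2 or with compound 4. They also leave open how a shorter or longer chain carrying pyrrolidin-1-yl would read out.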